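Swapping the ethoxybenzyl arm of compound 2 for a chlorobenzyl

The source may report more compounds than this note shows. Statements on the series, on what has been measured and on what is new or still open speak of the compounds shown alone.

Compound 2 `CCOc1ccc(Cc2nnc(CN(c3cccc(Cl)c3C)S(=O)(=O)c3ccc(C)cc3)o2)cc1` gives 3.98 nM in an assay on CHO cells for displacement of a labelled ligand from prostaglandin E2 receptor EP1 subtype (Homo sapiens) (a higher number here means a weaker inhibitor, a lower number a stronger inhibitor), the lowest of the three numbers recorded. Its closest neighbour, compound 3 `CCOc1ccc(Cc2nnc(CN(c3cccc(Cl)c3Cl)S(=O)(=O)c3ccc(C)cc3)o2)cc1`, gives 6.31 nM; compound 1 `COc1ccc(Cc2nnc(CN(c3cccc(C(F)(F)F)c3C)S(=O)(=O)c3ccc(C)cc3)o2)cc1` gives 63.1 nM. Among the compounds with values here, the one change followed by a single step, a 1.6-fold higher number from compound 2 to compound 3 (0.20 log units; within the scatter), lies on the aromatic ring bearing the sulfonamide nitrogen, not at the position changed here. Compound 4 `Cc1ccc(S(=O)(=O)N(Cc2nnc(Cc3cccc(Cl)c3)o2)c2cccc(Cl)c2C)cc1` carries 3-chlorophenyl in place of 4-ethoxyphenyl on a saturated chain carbon bound to an aromatic carbon. Within the data shown here, no measured step touches that benzyl arm; compound 1 and compound 2 differ at it and elsewhere, so their gap cannot be attributed. The step is therefore expected to be uncertain, leaning towards a higher number, a 6.3-fold higher number from compound 2 to compound 4 (0.80 log units; beyond the scatter). Compound 4 is estimated at 25 nM, between 5 nM and 125 nM.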

Compound 4, half-maximal inhibitory concentration: 158 nM
Estimate against measurement, compound 4: 6.3-fold (0.80 log units) below, outside the stated range (above it).
By their numbers in this assay, from the lowest: compounds 2 and 3 (each within the scatter of the next); then compound 1; then compound 4.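

Within the data shown here, the benzyl arm turns out to matter in this assay: 3-chlorophenyl in place of 4-ethoxyphenyl gives a 40-fold higher number from compound 2 to compound 4 (1.60 log units; beyond the scatter), the first measured step at this position. Set against a 1.6-fold higher number from compound 2 to compound 3 (0.20 log units; within the scatter), which stays within the scatter, it shows that the affinity of this series responds strongly to this arm. No measurement here accounts for the size of the step. Still open, on these data alone, is whether the rise follows from losing the ethoxy group or from gaining the chloro group. Neither a 4-chlorophenyl nor a 3-ethoxyphenyl arm appears among these compounds to separate the two.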